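The compounds below may be only part of what the source reports. "The series", "measured", "known", "first", "only" and "open" are said of these compounds alone.

Compound 1 `C#Cc1ccc(NC(=O)c2cn(CC(=O)OCC)nn2)cc1` and compound 2 `C#Cc1ccc(NC(=O)c2cn(CCOC(C)=O)nn2)cc1` share one core, while compound 3 `CCOC(=O)Cn1cc(-c2cccc(NC(=O)c3cn(Cc4ccccc4)nn3)c2)nn1` and compound 4 `CC(=O)OCCn1cc(-c2cccc(NC(=O)c3cn(Cc4ccccc4)nn3)c2)nn1` share another; the difference between the two cores is not broken down here. In a functional assay on B16 cells (Mus musculus) for cytotoxicity, read by MTT assay, with a stated time of 48 h (a lower number here means a stronger inhibitor, a higher number a weaker inhibitor), compound 1 yields only a limit, > 100000 nM, which is the limit noted as the limit of > 100000 nM in this assay, at which 1 of the 3 values shown sits. Compound 2 gives 79000 nM in this assay, and the step of an at least 1.2-fold lower number from compound 1 to compound 2 (0.10 log units; that floor lies within the scatter) accompanies the change (acetoxymethyl in place of ethoxycarbonyl on a saturated chain carbon bound to an aromatic nitrogen). Compound 3 gives 21000 nM in this assay, the lowest of the two numbers. Compound 4 differs from compound 3 by the same change, (acetoxymethyl in place of ethoxycarbonyl on a saturated chain carbon bound to an aromatic nitrogen). Because the earlier step of an at least 1.2-fold lower number from compound 1 to compound 2 (0.10 log units; that floor lies within the scatter) stayed within the scatter, compound 4 is expected to shift by about a 1.3-fold lower number from compound 3 to compound 4 (0.12 log units; within the scatter). The estimate for compound 4 is 16000 nM, expected to fall between 6000 nM and 45000 nM.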

Compound 4, half-maximal inhibitory concentration: 25100 nM
Estimate against measurement, compound 4: 1.6-fold (0.20 log units) below; measured number inside the range.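

In this assay acetoxymethyl in place of ethoxycarbonyl gives a 1.2-fold higher number from compound 3 to compound 4 (0.08 log units; within the scatter) and so, on the core of compound 3, the change has no effect that can be told from the scatter. Compound 1 stands at > 100000 nM in this assay and that value is a limit, not a number. This does not show that the change carries over alike from one core to the other, and the comparison reads: the same change on two cores in this assay, an at least 1.2-fold lower number (0.10 log units; that floor lies within the scatter) from compound 1 to compound 2 and a 1.2-fold higher number (0.08 log units; within the scatter) from compound 3 to compound 4; the limit leaves it open whether they differ

The compounds shown leave open what a carboxylic acid or an amine would do in this place, on a saturated chain carbon bound to an aromatic nitrogen. They also leave open how a longer chain carrying either ester would read on either core.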